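From propyl to pentyl on a shared core

This account rests on a few compounds, and the source may have more. Where it says the series, first, only, none or still open, it means among the compounds named here.

Compound 1 `Cc1c(C)c2c(c(C)c1N)CC(C)(CBr)O2` reads 16 mg/kg as a measured number
Compound 2 `CCCc1ccc(C2c3c(C)c(N)c(C)c(C)c3OC2(C)C)cc1` reads > 50 mg/kg as a limit only

In a functional assay on the whole organism with Mus musculus as the target (a lower number here means that less compound is needed, a higher number that more compound is needed for the effect), compound 2 stands at > 50 mg/kg and this is a limit of the assay, not a number. Compound 3 `CCCCCc1ccc(C2c3c(C)c(N)c(C)c(C)c3OC2(C)C)cc1` keeps the core of compound 2 and carries pentyl in place of propyl. The change is ethyl in place of hydrogen on a saturated chain carbon, three bonds along the chain from an aromatic carbon and it puts ethyl in place of hydrogen on the chain. For the measured compounds named here, no pair of measured compounds differs in one place, so no measured step guides this comparison. The expected change is a step that the limit leaves unreadable from compound 2 to compound 3 and it is expected to stay within the usual scatter, with no clear direction. For compound 3 the estimate is 60 mg/kg with an expected range from 25 mg/kg to 130 mg/kg and a real chance that the assay again reports only a limit.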

Compound 3, dose for 50% inhibition: 42.2 mg/kg
Beside the measured number, compound 3's estimate is 1.4-fold (0.15 log units) above it; the range from low to high includes it.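

With pentyl on the chain, the shared core gives a measured number in this assay, where the propyl compound gave only a limit. Across this change, the data show an at least 1.1-fold lower number from compound 2 to compound 3 (0.07 log units; that floor lies within the scatter), so they do not establish a real difference, though the true step could be larger than this floor. That size stays unknown because compound 2 has only a limit of the assay, not a number: the limit of > 50 mg/kg in this assay, at which 1 of the 3 values shown sits.

The compounds shown leave open whether a longer chain, such as heptyl, or an amine in place of the ethyl would give a lower number in this assay on this core. Compound 1 differs from both compounds in more than one place, so it offers no guide to this position.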